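Pyridin-4-yl replacing 3-fluorophenyl on a pyrazole carboxylic acid core

This account rests on a few compounds, and the source may have more. Where it says the series, first, only, none or still open, it means among the compounds named here.

Measured compounds:
Compound 1 `Cc1nn(-c2nc(-c3ccc(Cl)c(Cl)c3)c(SC(C)C)s2)c(C(=O)O)c1-c1cccc(F)c1` — 900 nM
Compound 2 `Cc1nn(-c2nc(-c3ccc(Cl)c(Cl)c3)c(SC(C)C)s2)c(C(=O)O)c1-c1cncc(C#N)c1` — 20000 nM
Compound 3 `Cc1nn(-c2nc(-c3ccc(Cl)c(Cl)c3)c(SC(C)C)s2)c(C(=O)O)c1-c1cccc(Cl)c1C` — 5100 nM

In a functional assay on BJAB cells (Homo sapiens) for antiproliferative activity, with a stated time of 4 days (a lower number here means that less compound is needed, a higher number that more compound is needed for the effect), compound 1 gives 900 nM and stands lowest of the three measured numbers; compound 3 is nearest and compound 2 furthest. Compound 4 `Cc1nn(-c2nc(-c3ccc(Cl)c(Cl)c3)c(SC(C)C)s2)c(C(=O)O)c1-c1ccncc1` has not yet been measured. It differs from compound 1 by pyridin-4-yl in place of 3-fluorophenyl on an aromatic carbon.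

Among the compounds with values here, two measured steps bear on this change, both starting from compound 1 and both replacing the 3-fluorophenyl. The step of a 22-fold higher number from compound 1 to compound 2 (1.35 log units; beyond the scatter), which brings in a six-membered ring with a nitrogen and a nitrile, is large. The step of a 5.7-fold higher number from compound 1 to compound 3 (0.75 log units; beyond the scatter), which keeps a ring of carbon only but alters its substituents, is modest. The pyridin-4-yl of compound 4 shares the ring nitrogen with compound 2 but lacks its nitrile, and sits between these cases. A higher number than compound 1 is therefore expected, beyond the scatter, but probably smaller than the step to compound 2: the estimate means a 5.6-fold higher number from compound 1 to compound 4 (0.74 log units; beyond the scatter). Compound 4 is estimated at 5000 nM, within a range of 1500 nM to 20000 nM.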

Compound 4, half-maximal effective concentration: 5900 nM
Beside the measured number, compound 4's estimate is 1.2-fold (0.07 log units) below it; low and high end bracket the measured number.
By their numbers in this assay, from the lowest: compound 1; then compounds 3 and 4 (each within the scatter of the next); then compound 2.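

In this assay, pyridin-4-yl carries no nitrile yet still gives a 6.6-fold higher number from compound 1 to compound 4 (0.82 log units; beyond the scatter), so the rise from the 3-fluorophenyl of compound 1 does not require a nitrile on the ring. The nitrile-bearing 5-cyanopyridin-3-yl nevertheless stands further up, with a 3.4-fold lower number from compound 2 to compound 4 (0.53 log units; beyond the scatter) showing that the two nitrogen-containing rings are not equivalent at this position. With a 1.2-fold higher number from compound 3 to compound 4 (0.06 log units; within the scatter), a ring with a nitrogen and the carbon-only 3-chloro-2-methylphenyl cannot be told apart, leaving the 3-fluorophenyl of compound 1 alone at the lowest number among these four compounds.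

Going by these compounds, it remains open whether an unsubstituted phenyl or a pyridin-3-yl without the nitrile would stay close to compound 1 or join compound 4. No supporting measurement here explains why these rings differ.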